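Swapping fluoro for trifluoromethoxy on compound 2

A few compounds are considered here, and "the series" means these few. Any claim that something is new, unique, unknown or untested is made for them only; others in the source may bear on it.

- Compound 1 `Cc1cc(=O)oc2cc(OCC(=O)c3cccc(C(F)(F)F)c3)ccc12` gives 38400 nM as a measured number
- Compound 2 `Cc1cc(=O)oc2cc(OCC(=O)c3ccc(F)cc3)ccc12` gives > 100000 nM as a limit
- Compound 3 `Cc1cc(=O)oc2cc(OCC(=O)c3ccc4c(c3)OCCCO4)ccc12` gives > 100000 nM as a limit

These values come from a functional assay on MCF7 cells (Homo sapiens) for antiproliferative activity, with a stated time of 96 h (on this read-out lower numbers stand for stronger inhibition and higher numbers for weaker inhibition), and all three compounds share the same core. Compound 2 stands at > 100000 nM in this test, which is a limit of the assay and not a number. Compound 2 thus sits at the limit of > 100000 nM in this assay, at which 2 of the 3 values shown sit, and has no exact place in the series.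

Compound 4 `Cc1cc(=O)oc2cc(OCC(=O)c3ccc(OC(F)(F)F)cc3)ccc12` keeps the rest of compound 2 and changes one group: trifluoromethoxy in place of fluoro on an aromatic carbon, para to a large group (trifluoromethoxy in place of fluoro on an aromatic carbon).

For the measured compounds named here, no measured pair here shows a single change of this kind, so the size of the step cannot be read directly. Going by the values given here, compound 1 carries a trifluoromethyl group and gives 38400 nM as the only measured number in the set. On that slim basis, a modest shift towards stronger inhibition is expected in this assay and compound 4 may still reach only the limit. The expected change an at least 1.6-fold lower number from compound 2 to compound 4 (0.22 log units; that floor lies within the scatter) is therefore small and uncertain. Compound 4 is estimated at 60000 nM (expected range 25000 nM to 100000 nM).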

Compound 4, half-maximal inhibitory concentration: > 100000 nM
Compound 4: a limit, no number (the forecaster's own chance of this, stated with the estimate: 50%); at least 1.6-fold (0.22 log units) between middle value and limit.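

In this assay compound 4 gives > 100000 nM as a limit of the assay, not a number. Compound 2 gives > 100000 nM as a limit as well. For the compounds shown here, no step between compound 2 and compound 4 can therefore be read. Still open, from the compounds shown here alone, is whether trifluoromethoxy in place of fluoro changes inhibition at all, and by how much.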